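Benzyl in place of thiadiazolyl on the amide nitrogen

A few compounds are considered here, and "the series" means these few. Any claim that something is new, unique, unknown or untested is made for them only; others in the source may bear on it.

Compound 1 `O=C(Cn1c(-c2ccccc2)cc(-c2ccccc2)c1-c1ccco1)Nc1nc2ccccc2s1` gives 89.9% in an ADME assay on HEK-293T cells (Homo sapiens) for cytotoxicity, read by MTT assay, with a stated time of 72 h, tested at 50 uM; a lower number here means less inhibition, a higher number more inhibition at the concentration tested (going by the name of the read-out). Compound 2 `CCc1nnc(NC(=O)Cn2c(-c3ccccc3)cc(-c3ccccc3)c2-c2ccco2)s1` gives 81% in this assay; the step of a number 8.9 percentage points lower from compound 1 to compound 2 (within the scatter) is the only measured one in the series, and it leaves compound 2 and compound 1 within the scatter of each other, so no ranking between them is warranted. Compound 3 `O=C(Cn1c(-c2ccccc2)cc(-c2ccccc2)c1-c1ccco1)NCc1ccccc1` is not yet measured. Among the measured compounds shown here, the change benzyl in place of 5-ethyl-1,3,4-thiadiazol-2-yl on an amide-type nitrogen sits at the same amide-type nitrogen that the one measured step altered, and that step was small. For the measured compounds named here, no measured pair exchanges an aromatic heterocycle for a benzyl group, so the only guidance is that one earlier swap at this position did not move the read-out beyond the scatter. A step of a number 7 percentage points lower from compound 2 to compound 3 (within the scatter) is therefore expected, with a wide range to reflect the unprecedented change. Compound 3 is estimated at 74%, between 48% and 95%.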

Compound 3, a percentage reported as inhibition, at one concentration (the size of the read-out at that concentration, not a potency): 72.4%
Compound 3: the middle estimate sits 1.6 percentage points above what was measured; the range from low to high includes it.
By their numbers in this assay, from the lowest: compounds 3, 2 and 1 (each within the scatter of the next, the first and the last beyond it).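

In this assay, the amide-type nitrogen now shows a step beyond the scatter: benzyl in place of 1,3-benzothiazol-2-yl gives a number 17.5 percentage points lower from compound 1 to compound 3 (beyond the scatter). Benzyl in place of 5-ethyl-1,3,4-thiadiazol-2-yl gives a number 8.6 percentage points lower from compound 2 to compound 3 (within the scatter), so this substituent can matter to the read-out, but only the pair at the two ends of the series is separated, and compound 2 cannot be ranked against either neighbour. No available evidence accounts for the difference between the benzothiazolyl and benzyl compounds.

Open, from the compounds shown here alone, is how the read-out responds on this nitrogen to phenyl, a plain ethyl chain or a chain ending in an amine. Also open, going by these compounds, is whether the step from compound 1 to compound 3 would hold with another group on the shared core.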